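A few compounds are considered here, and "the series" means these few. Any claim that something is new, unique, unknown or untested is made for them only; others in the source may bear on it.

Compound 1 `CN(C)c1ccc2nc(-c3c(Cl)nc(N)nc3N[C@@H]3C[C@H](CO)[C@@H](O)[C@H]3O)sc2c1` sits at > 25000 nM in an ADME assay on cells (Homo sapiens) for cytotoxicity, read by polymerase chain reaction, with a stated time of 3 days (a higher number here means that more compound is tolerated, a lower number that less compound is tolerated), which is a limit of the assay and not a number.
Compound 2 `CCNc1nc(C)c(-c2nc3ccccc3s2)c(N[C@@H]2C[C@H](CO)[C@@H](O)[C@H]2O)n1` gives 12000 nM in this assay.
Compound 3 `CCc1nc(N(C)C)nc(N[C@@H]2C[C@H](CO)[C@@H](O)[C@H]2O)c1-c1nc2ccccc2s1` sits at > 25000 nM in this assay, again a limit of the assay and not a number.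

Three compounds have been run in this assay. Compound 2 is the only one of them that returns a number; the other two stop at the limit of > 25000 nM in this assay, at which 2 of the 3 values shown sit. For the measured compounds named here, compound 2 therefore stands as the one compound whose tolerance could be pinned down, and no step between measured compounds can be drawn from this set, since none of the three differs from another in a single place.

Compound 4 `Cc1nc(Nc2nccs2)nc(N[C@@H]2C[C@H](CO)[C@@H](O)[C@H]2O)c1-c1nc2ccccc2s1` has not yet been measured. It is reached from compound 2 by one change: 1,3-thiazol-2-yl in place of ethyl on a nitrogen on an aromatic ring. Going by the values given here, with no measured step to lean on, the account can only expect that the step from compound 2 to compound 4 in this assay is modest, if anything a drift toward less compound being tolerated, and more likely within the usual scatter than beyond it. Compound 4 is therefore estimated at 10000 nM, within a range from 3000 nM to 30000 nM. The expected step is a 1.2-fold lower number from compound 2 to compound 4 (0.08 log units; within the scatter), with a limit rather than a number remaining a real possibility.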

Compound 4, half-maximal cytotoxic concentration: 15000 nM
Estimate against measurement, compound 4: 1.5-fold (0.18 log units) below, and the stated range covers the measured number.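

For the compounds shown here, the first single-place step in this assay is a 1.3-fold higher number from compound 2 to compound 4 (0.10 log units; within the scatter), with 1,3-thiazol-2-yl in place of ethyl on a nitrogen on an aromatic ring. Going by these compounds alone, this shows that, at this one position and in this one pair, an open ethyl group and a five-membered aromatic ring carrying hetero atoms cannot be told apart in this assay, something the earlier compounds, with no single-place step among them, could not show. Compound 4 also returns a number and not a limit of the assay, while the other two compounds shown remain at a limit and not a number: the limit of > 25000 nM in this assay, at which 2 of the 4 values shown sit.

From the compounds shown here alone, whether a longer chain such as hexyl, a phenyl ring or a carboxylic acid on this nitrogen would give a step beyond the scatter remains open. Steps to compound 1 and compound 3 cannot be read, since each differs from the others in more than one place, and the single step shown says nothing about changes elsewhere on the shared core.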